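The source may hold more compounds than are shown below. What is called first, only, known or untested is meant among the compounds shown, and "the series" means these compounds.

Of the compounds shown here, three built on one shared core have been tested in a functional assay on MCF7 cells (Homo sapiens) for cytotoxicity, read by MTT assay, with a stated time of 24 h, tested at 6.4 ug/mL; a lower number here means a weaker effect, a higher number a stronger effect of the compound at the concentration tested. Compound 1 `Cn1c(-c2ccc(NC(=O)CCl)cc2)nc(-c2ccccc2)c1-c1ccccc1` gives 14.2%. Compound 2 `Cn1c(-c2ccc(NC(=O)CSc3nc4ccccc4o3)cc2)nc(-c2ccccc2)c1-c1ccccc1` gives 42.3%, a change of a number 28.1 percentage points higher from compound 1 to compound 2 (beyond the scatter). Compound 3 `Cn1nnnc1SCC(=O)Nc1ccc(-c2nc(-c3ccccc3)c(-c3ccccc3)n2C)cc1` gives 55.9%, the highest of the three numbers, with steps of a number 41.7 percentage points higher from compound 1 to compound 3 (beyond the scatter) and a number 13.6 percentage points higher from compound 2 to compound 3 (beyond the scatter). Compound 4 `Cn1ccnc1SCC(=O)Nc1ccc(-c2nc(-c3ccccc3)c(-c3ccccc3)n2C)cc1` is not yet measured and differs from compound 3 in one place: 1-methyl-1H-imidazol-2-yl in place of 1-methyl-1H-tetrazol-5-yl on a sulfur. Among the measured compounds shown here, the only measured step bearing on this change is a number 13.6 percentage points higher from compound 2 to compound 3 (beyond the scatter), where one five-membered aromatic ring on the sulfur replaced a different ring with a modest gain. Since compound 4 again carries a ring on the sulfur, a modest step downward or none beyond the scatter is expected, a number 10.9 percentage points lower from compound 3 to compound 4 (beyond the scatter). Compound 4 is therefore estimated at 45%, within 25% to 65%.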

Compound 4, a percentage reported as activity, at one concentration (the size of the read-out at that concentration, not a potency): 27.2%
Compound 4: the middle estimate sits 17.8 percentage points above what was measured; the range from low to high includes it.
By their numbers in this assay, from the lowest: compound 1; then compound 4; then compound 2; then compound 3.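

In this assay, among the compounds shown here, exchanging 1-methyl-1H-tetrazol-5-yl for 1-methyl-1H-imidazol-2-yl on the sulfur, with the same count of heavy atoms, still gives a clear loss (a number 28.7 percentage points lower from compound 3 to compound 4 (beyond the scatter)), so which ring sits here matters, not only that a ring is present. The 1-methyl-1H-imidazol-2-yl ring also trails 1,3-benzoxazol-2-yl (a number 15.1 percentage points lower from compound 2 to compound 4 (beyond the scatter)), but the group as a whole still beats chloro (a number 13 percentage points higher from compound 1 to compound 4 (beyond the scatter)). No measurement shown explains these differences. Where a phenyl or triazole ring on the sulfur would fall remains open.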